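The source may hold more compounds than are shown below. What is called first, only, known or untested is meant among the compounds shown, and "the series" means these compounds.

Measured so far:
Compound 1 `NNC(=O)CCc1ccncc1-c1ccc2ccccc2c1`: > 10000 nM
Compound 2 `CNC(=O)/C=C/c1ccncc1-c1ccc2cc[nH]c2c1`: 7840 nM

Both compounds were tested in a functional assay on A549 cells (Homo sapiens) for inhibition, read by sulforhodamine B assay, with a stated time of 72 h; a higher number here means a weaker inhibitor of growth, a lower number a stronger inhibitor of growth. Compound 1 stands at > 10000 nM, which is a limit of the assay and not an exact number. This limit applies to one of the two results so far, as the limit of > 10000 nM in this assay, at which 1 of the 2 values shown sits, shows. Compound 2 gives a measured number, 7840 nM.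

The next compound, compound 3 `O=C(O)CCc1ccncc1-c1ccc2ccccc2c1`, keeps the core of compound 1 and changes only the end of its chain. Hydroxy takes the place of aminoamino on a carbonyl carbon, so 2-(aminocarbamoyl)ethyl becomes 2-carboxyethyl (hydroxy in place of aminoamino on a carbonyl carbon).

Going by the values given here, no measured pair of compounds shows what this kind of change does, so there is no direct guide to its size. The starting point is also only a limit, so the expectation in this assay is for no change beyond the usual scatter, and compound 3 may well reach the same limit. The expected step is a step that the limit leaves unreadable from compound 1 to compound 3. For compound 3, the estimated value is 15000 nM, with an expected range of 7000 nM to 30000 nM.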

Compound 3, concentration for 50% growth inhibition: > 10000 nM
Compound 3: only a limit was reported; the forecaster's own chance of this, stated with the estimate: 75%; the middle value is on the limit's open side.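

Compound 1 gives > 10000 nM, which is a limit of the assay and not a number. Compound 3 gives > 10000 nM, also a limit. No step from compound 1 to compound 3 can be read, because both results rest on the same limit: the limit of > 10000 nM in this assay, at which 2 of the 3 values shown sit.

Still open, as far as these compounds go, is whether hydroxy in place of aminoamino on a carbonyl carbon shifts growth inhibition at all, and by how much.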